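The compounds below may be only part of what the source reports. "The series", "measured", "known", "first", "only" and "open" are said of these compounds alone.

Measured in an ADME assay on CCRF-CEM cells (Homo sapiens) for antiproliferative activity, with a stated time of 48 h; a higher number here means a weaker inhibitor, a lower number a stronger inhibitor:
- compound 1 `C=C(Br)C(=O)Nc1ccc(/C=C/C(=O)c2ccccc2)cc1`: 4000 nM
- compound 2 `C=C(Br)C(=O)Nc1ccc(/C=C/C(=O)c2ccc(OCC)cc2)cc1`: 750 nM
- compound 3 `Nc1ccc(/C=C/C(=O)c2ccccc2)cc1`: not yet measured

Compound 1 holds the higher of the two numbers and is the weaker inhibitor of the measured pair. Among the measured compounds shown here, the only measured step is a 5.3-fold lower number from compound 1 to compound 2 (0.73 log units; beyond the scatter), with ethoxy in place of hydrogen on an aromatic carbon.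

Compound 3 differs from compound 1 by hydrogen in place of (1-bromoethenyl)carbonyl on a nitrogen on an aromatic ring. In words, this is hydrogen in place of (1-bromoethenyl)carbonyl on a nitrogen on an aromatic ring.

The measured step bears on this only indirectly, since it concerns another place on the shared core. It gives a sense of scale: one small addition already moved the number by a modest amount. Both measured compounds carry the (1-bromoethenyl)carbonyl, so the data do not show what its loss does. Removing the whole group is the larger structural change, and a higher number, meaning weaker inhibition, is expected, though with wide uncertainty. The expected step is a 4.0-fold higher number from compound 1 to compound 3 (0.60 log units; beyond the scatter). For compound 3 the estimate is 16000 nM, with an expected range from 5000 nM to 50000 nM.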

Compound 3, half-maximal inhibitory concentration: 34000 nM
Estimate against measurement, compound 3: 2.1-fold (0.33 log units) below; measured number inside the range.
By their numbers in this assay, from the lowest: compound 2; then compound 1; then compound 3.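

In this assay, removing the (1-bromoethenyl)carbonyl from the nitrogen on the aromatic ring gives an 8.5-fold higher number from compound 1 to compound 3 (0.93 log units; beyond the scatter), showing that this position also affects the read-out, which the earlier pair could not show because both of its members carry the group. Compound 3 still gives a numerical reading of 34000 nM, so within this short series the (1-bromoethenyl)carbonyl strengthens inhibition but is not needed for a measurable value. The data on hand offer no explanation for the size of this step.

Going by these compounds, the step removes the whole group at once, so it remains open how much depends on the bromine, the carbon-carbon double bond or the carbonyl, a question that an acetyl or a propenoyl on the same nitrogen would help to separate. On these data alone, it also remains open whether ethoxy in place of hydrogen on an aromatic carbon, seen so far only with the (1-bromoethenyl)carbonyl present, would change the number in the same direction on the free amino compound.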